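Working notes: the step from compound 3 to compound 4

The compounds below may be only part of what the source reports. "The series", "measured", "known", "first", "only" and "open" are said of these compounds alone.

Measured compounds and their numbers:
compound 1 `C=C1C(=O)O[C@@H](c2ccccc2)[C@H]1C`: 143%
compound 2 `C=C1C(=O)O[C@H](c2ccc3ccccc3c2)[C@H]1C`: 139%
compound 3 `C=C1C(=O)O[C@H](c2ccc(OC)cc2)[C@H]1c1ccccc1`: 80%

In a functional assay on PANC-1 cells (Homo sapiens) for cytotoxicity, read by MTT assay, with a stated time of 72 h, tested at 1 uM (on this read-out higher numbers stand for a weaker effect at the one concentration tested and lower numbers for a stronger effect), compound 3 stands lowest of the three numbers. The nearest of the others, compound 2, lies higher by an amount beyond the scatter, and compound 1 lies higher still, also beyond the scatter. Among the measured compounds shown here, no pair of measured compounds differs in only one place, so no single change has yet been sized in this assay.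

Compound 4 `C=C1C(=O)O[C@H](c2ccc(C(F)(F)F)cc2)[C@H]1c1ccccc1` differs from compound 3 in one place: trifluoromethyl in place of methoxy on an aromatic carbon. For the measured compounds named here, nothing among the measured compounds isolates this change, so its size is open; the step from compound 3 to compound 4 is expected to be a number 5 percentage points higher from compound 3 to compound 4 (within the scatter), small and possibly none beyond the scatter. Compound 4 is estimated at 85% in this assay, with a range from 55% to 120%.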

Compound 4, a percentage reported as activity, at one concentration (the size of the read-out at that concentration, not a potency): 152%
Compound 4: middle estimate off by 67 percentage points, on the low side; measured number outside the range, above it.
By their numbers in this assay, from the lowest: compound 3; then compounds 2, 1 and 4 (each within the scatter of the next, the first and the last beyond it).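

In this assay, trifluoromethyl in place of methoxy on an aromatic carbon, para to a large group, gives the first single change sized in this series: a number 72 percentage points higher from compound 3 to compound 4 (beyond the scatter) and so a large loss of effect at the one concentration tested. This position is therefore not indifferent to its substituent, and the methoxy compound has the stronger effect of the pair. No available measurement explains the step.

Going by these compounds, whether the loss follows from adding trifluoromethyl or from removing methoxy stays open. On these data alone, it is also open whether a hydroxyl, an amine or a carboxylic acid at this place would read like compound 3 or compound 4.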